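The source may report more compounds than this note shows. Statements on the series, on what has been measured and on what is new or still open speak of the compounds shown alone.

Compound 1 `NS(=O)(=O)OC[C@@H]1C[C@@H](n2nnc3c(NCc4ccccc4F)ncnc32)C[C@@H]1O`: 6.11 nM in an assay on a protein complex for inhibition of NEDD8 activating enzyme (Homo sapiens), read by HTRF, with a stated time of 2 h, in the presence of a further agent that is not named here; a higher number here means a weaker inhibitor, a lower number a stronger inhibitor.
Compound 2 `CCCCCCNc1ncnc2c1nnn2[C@@H]1C[C@@H](COS(N)(=O)=O)[C@@H](O)C1`: 21.1 nM in this assay.
Compound 3 `NS(=O)(=O)OC[C@@H]1C[C@@H](n2nnc3c(NC4CCCC4)ncnc32)C[C@@H]1O`: > 10000 nM in this assay, a limit of the assay rather than a measured number.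

Compound 3 is the weakest of the three measured compounds, resting at the assay limit (the limit of > 10000 nM in this assay, at which 1 of the 3 values shown sits). Compound 4 `NS(=O)(=O)OC[C@@H]1C[C@@H](n2nnc3c(Nc4n[nH]c5ccccc45)ncnc32)C[C@@H]1O` differs from it in one place: 1H-indazol-3-yl in place of cyclopentyl on a nitrogen on an aromatic ring. Going by the values given here, two measured steps bear on this position: an at least 1600-fold higher number from compound 1 to compound 3 (3.21 log units; beyond the scatter) and an at least 470-fold higher number from compound 2 to compound 3 (2.67 log units; beyond the scatter). Both show that the cyclopentyl group on this nitrogen is far weaker than the 2-fluorobenzyl or hexyl groups. Compound 4 places an aromatic group on that nitrogen, so some recovery of potency is expected, although the measured steps cannot say how much. The expected step in this assay is an at least 20-fold lower number from compound 3 to compound 4 (1.30 log units; beyond the scatter). Compound 4 is estimated at 500 nM, within a range of 20 nM to 10000 nM.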

Compound 4, half-maximal inhibitory concentration: > 10000 nM
Compound 4: a limit, no number (the forecaster's own chance of this, stated with the estimate: 25%); at least 20-fold (1.30 log units) between middle value and limit.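

An aromatic group on this nitrogen does not by itself bring potency back, as 1H-indazol-3-yl in place of 2-fluorobenzyl gives an at least 1600-fold higher number from compound 1 to compound 4 (3.21 log units; beyond the scatter), and in place of hexyl gives an at least 470-fold higher number from compound 2 to compound 4 (2.67 log units; beyond the scatter). Compound 4 joins compound 3 at a limit of the assay, so the step between them cannot be read: the limit of > 10000 nM in this assay, at which 2 of the 4 values shown sit. Among these four compounds, the two groups joined to the nitrogen through a ring atom sit at the limit, while the two joined through a saturated chain carbon do not.

As far as these compounds go, whether a plain phenyl on this nitrogen would behave like 1H-indazol-3-yl remains open. So does whether a shorter chain such as butyl or an unsubstituted benzyl would hold the potency of compound 1 and compound 2.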